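The source may report more compounds than this note shows. Statements on the series, on what has been measured and on what is new or still open speak of the compounds shown alone.

Compound 1 `COc1cc(C(=O)c2sc(-c3ccc(-c4ccccc4)cc3)cc2N)cc(OC)c1OC` — in a functional assay on MOLT-4 cells (Homo sapiens) for antiproliferative activity (on this read-out higher numbers stand for weaker inhibition and lower numbers for stronger inhibition), compound 1 gives > 10000 nM, which is a limit of the assay rather than a number.
Compound 2 `COc1cc(C(=O)c2sc(-c3ccc(Br)cc3)cc2N)cc(OC)c1OC` — in this assay compound 2 gives 92 nM.
Compound 3 `COc1cc(C(=O)c2sc(-c3cccc([N+](=O)[O-])c3)cc2N)cc(OC)c1OC` — in this assay compound 3 gives 7.5 nM.

The three compounds share one core and differ only in the aromatic group carried on it. Compound 3 stands lowest of the two numbers given; its nearest neighbour is compound 2, and the gap is a 12-fold lower number from compound 2 to compound 3 (1.09 log units; beyond the scatter), beyond the scatter.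

Compound 4 `COc1cc(C(=O)c2sc(-c3ccc(C(F)(F)F)cc3)cc2N)cc(OC)c1OC` has not yet been measured. 4-(trifluoromethyl)phenyl in place of 3-nitrophenyl on an aromatic carbon

Both measured steps bear on this change. The step of an at least 100-fold lower number from compound 1 to compound 2 (2.03 log units; beyond the scatter) shows how strongly the group at this position can move the number, with the phenyl compound sitting at a limit (the limit of > 10000 nM in this assay, at which 1 of the 3 values shown sits). The step of a 12-fold lower number from compound 2 to compound 3 (1.09 log units; beyond the scatter) then shows a further clear gain from 4-bromophenyl to 3-nitrophenyl. The 4-(trifluoromethyl)phenyl of compound 4 shares its substitution pattern with the 4-bromophenyl of compound 2 rather than with the 3-nitrophenyl of compound 3, so the number is expected to rise again, roughly undoing the step to compound 3, with a step of a 20-fold higher number from compound 3 to compound 4 (1.30 log units; beyond the scatter) expected. Compound 4 is therefore estimated at about 150 nM, within 30 nM to 1500 nM.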

Compound 4, half-maximal inhibitory concentration: 250 nM
Compound 4: middle estimate off by 1.7-fold (0.22 log units), on the low side, and the stated range covers the measured number.
By their numbers in this assay, from the lowest: compound 3; then compound 2; then compound 4. At a limit, above all of these: compound 1.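

The 3-nitrophenyl group of compound 3 now stands apart from two groups with a 4-substituted phenyl ring, not just one: in this assay there is a 33-fold higher number from compound 3 to compound 4 (1.52 log units; beyond the scatter), so the low number of compound 3 does not carry over to 4-(trifluoromethyl)phenyl. Exchanging bromo for trifluoromethyl on the phenyl ring moves the number much less, although the step remains beyond the scatter, with a 2.7-fold higher number from compound 2 to compound 4 (0.43 log units; beyond the scatter), so these two groups are close but not interchangeable here. A small group on this phenyl ring again compares well with the extra phenyl of compound 1, with an at least 40-fold lower number from compound 1 to compound 4 (1.60 log units; beyond the scatter), but this step starts from a limit rather than a number: the limit of > 10000 nM in this assay, at which 1 of the 4 values shown sits.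

The compounds shown do not separate the nitro group itself from its place on the phenyl ring, as compound 3 is the only one with a 3-substituted ring; a 4-nitrophenyl or a 3-bromophenyl group would pull these two apart. They also leave open how an amine or a carboxylic acid on this phenyl ring would read in this assay.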